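This account rests on a few compounds, and the source may have more. Where it says the series, first, only, none or still open, it means among the compounds named here.

Compound 1, `COc1cc(/C=C/C(C)=O)ccc1OCc1cn(-c2ccccc2CO)nn1`, gives 50300 nM in a functional assay on PC-3 cells (Homo sapiens) for antiproliferative activity, read by MTT assay, with a stated time of 48 h; on this read-out lower numbers stand for stronger inhibition and higher numbers for weaker inhibition.
Compound 2, `COc1cccc(-n2cc(COc3ccc(/C=C/C(C)=O)cc3OC)nn2)c1`, gives 31600 nM in this assay.

Among the two numbers available, compound 2 stands with the lowest number in this assay, but the single step that joins the pair, a 1.6-fold lower number from compound 1 to compound 2 (0.20 log units; within the scatter), lies within the scatter, so the two values cannot be told apart and neither compound can be called the more active one. Compound 3, `COc1cc(/C=C/C(C)=O)ccc1OCc1cn(-c2ccc(C)cc2)nn1`, has not yet been measured in this assay. It differs from compound 2 in one place: 4-methylphenyl in place of 3-methoxyphenyl on an aromatic nitrogen. Among the compounds with values here, only one measured step bears on a change of the aryl group at this aromatic nitrogen, namely a 1.6-fold lower number from compound 1 to compound 2 (0.20 log units; within the scatter), and that step stayed within the scatter. With nothing beyond the scatter seen so far for a swap at this position, compound 3 is expected to land close to compound 2, with a step of a 1.1-fold higher number from compound 2 to compound 3 (0.04 log units; within the scatter), which means no shift beyond the scatter is anticipated in either direction. Compound 3 is therefore estimated at 35000 nM, within a range from 12000 nM to 100000 nM.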

Compound 3, half-maximal inhibitory concentration: 58100 nM
Estimate against measurement, compound 3: 1.7-fold (0.22 log units) below; measured number inside the range.
By their numbers in this assay, from the lowest: compounds 2, 1 and 3 (each within the scatter of the next).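

In this assay, 4-methylphenyl brings a third aryl group onto this aromatic nitrogen, with a 1.8-fold higher number from compound 2 to compound 3 (0.26 log units; within the scatter) and a 1.2-fold higher number from compound 1 to compound 3 (0.06 log units; within the scatter), so neither new step leaves the scatter. Within the data shown here, the earlier pair had offered only one such step; now all three pairs among compound 1, compound 2 and compound 3 stay within the scatter, and none of the three compounds can be called more active than another. The swap from 3-methoxyphenyl to 4-methylphenyl also gives up the single hydrogen-bond acceptor of the leaving group, and this too comes with no shift beyond the scatter, though no measurement at hand accounts for these values.

These compounds leave open whether an amine or a carboxylic acid on the phenyl ring, or a longer alkyl chain in place of the aryl group on this nitrogen, would move the number beyond the scatter. They also leave open whether a change elsewhere in the shared core, such as in the methoxy group, would do so.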